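The source may hold more compounds than are shown below. What is called first, only, known or untested is meant among the compounds shown, and "the series" means these compounds.

Working notes on a small thienopyrimidine set tested in a functional assay on CHO-K1 cells for antagonist activity at adenosine receptor A1 (Homo sapiens), read by a beta-galactosidase reporter and cAMP accumulation, with stated times of 15 min and 6 h; on this read-out higher numbers stand for weaker inhibition and lower numbers for stronger inhibition. Compound 1 `Cc1ccc(-c2nc(N)c3ccsc3n2)o1` gives 493 nM, compound 2 `Nc1nc(-c2ncco2)nc2sc(Cc3ccccc3)cc12` gives 310 nM, and compound 3 `N#Cc1cccc(-c2nc(N)c3cc(Cc4ccccc4Cl)sc3n2)c1` gives 24.8 nM. Compound 2 thus holds the second highest number of the three: its number and that of compound 1 lie within the scatter of each other, while compound 3 sits well beyond the scatter on the lower side.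

Compound 4 `Nc1nc(-c2ccccn2)nc2sc(Cc3ccccc3)cc12` is not yet measured. It differs from compound 2 by pyridin-2-yl in place of 1,3-oxazol-2-yl on an aromatic carbon on the shared core. Among the compounds with values here, no measured pair shows this change. A modest step toward lower numbers, at the edge of the scatter, is expected for a 2.1-fold lower number from compound 2 to compound 4 (0.32 log units; beyond the scatter). Compound 4 is estimated at 150 nM, within 40 nM to 500 nM.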

Compound 4, inhibition constant: 3710 nM
Compound 4: middle estimate off by 25-fold (1.39 log units), on the low side; the whole stated range lies below it.
By their numbers in this assay, from the lowest: compound 3; then compounds 2 and 1 (each within the scatter of the next); then compound 4.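

In this assay, pyridin-2-yl in place of 1,3-oxazol-2-yl on the aromatic carbon between two ring nitrogen atoms gives a 12-fold higher number from compound 2 to compound 4 (1.08 log units; beyond the scatter) with the rest of the structure unchanged. Within the data shown here, this position therefore responds strongly to the ring it carries, which the earlier compounds, differing in several places, could not show. No measurement at hand explains the step.

As far as these compounds go, whether ring size or the count of hetero atoms carries the step stays open. So does the outcome with an amine or a carboxylic acid on this carbon.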